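The compounds below may be only part of what the source reports. "The series", "measured", "known", "first", "only" and "open" are said of these compounds alone.

Measured in a functional assay on A549 cells (Homo sapiens) for antiproliferative activity, read by MTT assay; on this read-out lower numbers stand for stronger inhibition and higher numbers for weaker inhibition:
- Compound 1 `Cn1c(=O)c(=O)n(C2CCCC2)c2nc(N/N=C/c3ccc(C(F)(F)F)cc3)ncc21`: 40600 nM
- Compound 2 `COc1ccc(/C=N/Nc2ncc3c(n2)n(C2CCCC2)c(=O)c(=O)n3C)c(OC)c1`: > 100000 nM (a limit)
- Compound 3 `Cn1c(=O)c(=O)n(C2CCCC2)c2nc(N/N=C/c3cccc(O)c3)ncc21`: > 100000 nM (a limit)

Only compound 1 has a measured number in this series. Compound 3 stands at > 100000 nM, which is a limit of the assay and not a number.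

Compound 4 `Cn1c(=O)c(=O)n(C2CCCC2)c2nc(N/N=C/c3ccc(F)cc3F)ncc21` has not yet been measured in this assay. It replaces the 3-hydroxyphenyl of compound 3 with 2,4-difluorophenyl, on a carbon with a double bond to nitrogen: 2,4-difluorophenyl in place of 3-hydroxyphenyl on a carbon with a double bond to nitrogen.

Within the data shown here, two measured steps bear on this change. They are an at least 2.4-fold higher number from compound 1 to compound 2 (0.39 log units; beyond the scatter) and an at least 2.4-fold higher number from compound 1 to compound 3 (0.39 log units; beyond the scatter), and both lie beyond the scatter. Each leaves the 4-(trifluoromethyl)phenyl of compound 1 for a group without fluorine, and each ends at the limit. Compound 4 keeps fluorine on its phenyl ring, so it is expected to fall nearer compound 1, although it may still reach the limit. A modest move towards a lower number is expected, an at least 1.6-fold lower number from compound 3 to compound 4 (0.22 log units; that floor lies within the scatter). Compound 4 is estimated at 60000 nM, with an expected range of 25000 nM to 120000 nM.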

Compound 4, half-maximal inhibitory concentration: 18300 nM
Compound 4: middle estimate off by 3.3-fold (0.52 log units), on the high side; the whole stated range lies above it.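

In this assay the change to 2,4-difluorophenyl gives an at least 5.4-fold lower number from compound 3 to compound 4 (0.73 log units; beyond the scatter) and an at least 5.4-fold lower number from compound 2 to compound 4 (0.73 log units; beyond the scatter) on this carbon with a double bond to nitrogen, so this place can carry a measured gain and not only losses. The group also improves on the earlier best, with a 2.2-fold lower number from compound 1 to compound 4 (0.35 log units; beyond the scatter) in favour of 2,4-difluorophenyl, which makes compound 4 the strongest of the four. Among these four, both compounds with fluorine on the phenyl ring give a measured number and neither compound without it does, and no compound shown goes against this.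

Whether fluorine itself matters stays open, since a chlorophenyl or a pyridine ring at this place could answer that and neither is among the compounds shown. Compound 2 and compound 3 also stay unordered, and the step between them cannot be read: the limit of > 100000 nM in this assay, at which 2 of the 4 values shown sit.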